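From ethoxy to pentyloxy on the shared core

The source may report more compounds than this note shows. Statements on the series, on what has been measured and on what is new or still open speak of the compounds shown alone.

In a functional assay on DLD-1 cells (Homo sapiens) for cytotoxicity, with a stated time of 48 h (a higher number here means a weaker inhibitor, a lower number a stronger inhibitor), compound 1 `Cc1ccc2c(=O)cc(/C=C/[S+](C)[O-])oc2c1` gives 7000 nM and compound 2 `CCOc1ccc2oc(/C=C/[S+](C)[O-])cc(=O)c2c1` gives 4900 nM. Compound 2 therefore stands within the scatter of compound 1, and the pair shows no trend. Compound 3 `CCCCCOc1ccc2oc(/C=C/[S+](C)[O-])cc(=O)c2c1` extends the ethoxy of compound 2 to pentyloxy: propyl in place of hydrogen on a saturated chain carbon, two bonds along the chain from an oxygen on an aromatic ring. Among the measured compounds shown here, no measured step in this assay shows the effect of a change at this chain, so any expectation is weakly supported. The expected step is modest, toward a lower number: a 1.6-fold lower number from compound 2 to compound 3 (0.21 log units; within the scatter). For compound 3 the estimated value is 3000 nM, with an expected range of 1200 nM to 7500 nM.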

Compound 3, half-maximal inhibitory concentration: 6600 nM
Compound 3: middle estimate off by 2.2-fold (0.34 log units), on the low side, and the stated range covers the measured number.
By their numbers in this assay, from the lowest: compounds 2, 3 and 1 (each within the scatter of the next).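

In this assay, among the compounds shown here, the change from ethoxy to pentyloxy on the shared core gives a 1.3-fold higher number from compound 2 to compound 3 (0.13 log units; within the scatter) and is the only step read at this chain. Adding propyl at this place therefore leaves the number within the scatter, so this extension brings no measurable gain or loss in cytotoxicity. No measurement given here bears on the reason for this result. Still open, from the compounds shown here alone, is a chain longer than pentyloxy, or one ending in an amine or a carboxylic acid. Going by these compounds, whether any of these moves the number beyond the scatter remains unknown.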